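The compounds below may be only part of what the source reports. "The series", "measured", "known", "first", "only" and "open" are said of these compounds alone.

Measured so far:
- compound 1 `CC(C)(C)Sc1c(CC(C)(C)C(=O)O)n(Cc2ccc(Cl)cc2)c2ccc(OCc3ccc4cccnc4n3)cc12`: 6 nM
- compound 2 `CC(COc1ccc2c(c1)c(SC(C)(C)C)c(CC(C)(C)C(=O)O)n2Cc1ccc(Cl)cc1)c1ccccn1`: 4 nM

Both numbers come from a functional assay for inhibition, with Homo sapiens as the target; a higher number here means a weaker inhibitor, a lower number a stronger inhibitor. Compound 2 stands level with compound 1, as the two values lie within the usual scatter of each other.

The next compound is compound 3 `C[C@H](COc1ccc2c(c1)c(SC(C)(C)C)c(CC(C)(C)C(=O)O)n2Cc1ccc(Cl)cc1)c1ccccn1`. Its difference from compound 2 is purely one of how the structure is drawn in three dimensions: the two compounds have the same atoms and bonds; at least one stereo element is drawn with a configuration in one of them and without one in the other: 1 of 1 stereo elements differ; a stereocentre at a saturated chain carbon is drawn without a configuration in compound 2 and S in compound 3.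

Among the compounds with values here, only one measured step exists, a 1.5-fold lower number from compound 1 to compound 2 (0.18 log units; within the scatter). That step exchanged one group for another and involved no change of configuration, so it offers no direct guide here. Within the data shown here, no pair of compounds in this set shows what fixing a configuration does, and so neither direction can be favoured.

The expectation in this assay therefore stays close to compound 2 at 4 nM. The expected change is a 1.1-fold lower number from compound 2 to compound 3 (0.06 log units; within the scatter), which would be no step beyond the scatter. For compound 3 the estimated value is 3.5 nM, with an expected range of 1.3 nM to 12 nM.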

Compound 3, half-maximal inhibitory concentration: 3 nM
For compound 3 the middle estimate is 1.2-fold (0.07 log units) above the measured one; measured number inside the range.
By their numbers in this assay, from the lowest: compounds 3, 2 and 1 (each within the scatter of the next).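

In this assay, within the data shown here, drawing the stereocentre at the saturated chain carbon as S gives a 1.3-fold lower number from compound 2 to compound 3 (0.12 log units; within the scatter), so compound 3 stands level with compound 2 and fixing the configuration brings no step that can be told from the scatter. With the configuration fixed, the group of 8 heavy atoms with one six-membered aromatic ring, in place of the group of 10 heavy atoms with two such rings, gives a 2.0-fold lower number from compound 1 to compound 3 (0.30 log units; within the scatter), so this exchange also leaves the two compounds level. What this pair can say about configuration is limited because of what it sets side by side: the fact that one of compounds 2 and 3 is drawn with a defined configuration and the other without, at the place where they differ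

Going by these compounds, how the R configuration at this carbon would read in this assay stays open, and with it whether the choice between S and R matters at all at this position. Also open, on these data alone, is whether an amine or a longer chain on this saturated chain carbon would keep the number at the level shared by these three compounds.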